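Growth inhibition notes: from compound 3 to compound 4

This account rests on a few compounds, and the source may have more. Where it says the series, first, only, none or still open, it means among the compounds named here.

In a functional assay on Hs 683 cells (Homo sapiens) for inhibition, read by MTT assay, with a stated time of 72 h (on this read-out lower numbers stand for stronger inhibition of growth and higher numbers for weaker inhibition of growth), compound 1 (`CC(C)C(C)(C)[Si](C)(C)OC[C@H]1O[C@@H](n2ccc(=O)[nH]c2=O)[C@H](O)[C@@H]1O`) gives > 100000 nM as a limit of the assay, not a number. Compound 2 (`CC(C)[Si]1(C(C)C)OC[C@H]2O[C@@H](n3ccc(=O)[nH]c3=O)[C@H](O)[C@@H]2O[Si](C(C)C)(C(C)C)O1`) gives 83000 nM and compound 3 (`CC(=O)O[C@@H]1[C@H](OC(C)=O)[C@@H](CO[Si](c2ccccc2)(c2ccccc2)C(C)(C)C)O[C@H]1n1ccc(=O)[nH]c1=O`) gives 29000 nM as the lowest number shown, with its gap to compound 2 beyond the usual scatter. The change to compound 4 (`CC(=O)O[C@@H]1[C@H](OC(C)=O)[C@@H](CO[Si](c2ccccc2)(c2ccccc2)C(C)(C)C)O[C@H]1n1ccc(=O)n(C(=O)c2ccccc2)c1=O`) is benzoyl in place of hydrogen on an aromatic nitrogen in the form of benzoyl in place of hydrogen on an aromatic nitrogen. For the measured compounds named here, no measured pair shows this change, so no step beyond the scatter is expected in this assay and any drift should lean toward lower numbers. The expectation starts from compound 3 at 29000 nM as its anchor. The expected change is a 1.3-fold lower number from compound 3 to compound 4 (0.12 log units; within the scatter) in size. For compound 4 the estimate is 22000 nM with an expected range from 7000 nM to 70000 nM as its bounds.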

Compound 4, concentration for 50% growth inhibition: 35000 nM
Compound 4: middle estimate off by 1.6-fold (0.20 log units), on the low side, within the range that was stated.
By their numbers in this assay, from the lowest: compounds 3 and 4 (each within the scatter of the next); then compound 2. At a limit, above all of these: compound 1.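

The aromatic nitrogen now has a measured step: in this assay, benzoyl in place of hydrogen gives a 1.2-fold higher number from compound 3 to compound 4 (0.08 log units; within the scatter). This position therefore takes benzoyl, with its six-membered aromatic ring of carbon only, without a step beyond the scatter. No measured property available here bears on this step.

On these data alone, whether methyl, acetyl or an aminoethyl chain on the same nitrogen would also stay within the scatter remains open. Also open, as far as these compounds go, is whether benzoyl reads the same with the silyl ether of compound 2 in place of the groups of compound 3.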